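Ethoxy to bromoanilino on the shared core

The source may report more compounds than this note shows. Statements on the series, on what has been measured and on what is new or still open speak of the compounds shown alone.

Measured so far, each in a functional assay on SAOS-2 cells (Homo sapiens) for antiproliferative activity, read by MTT assay, with a stated time of 72 h; on this read-out lower numbers stand for stronger inhibition and higher numbers for weaker inhibition:
Compound 1 `CCOC1=C(C(=O)c2ccccc2)C(c2ccc(Br)cc2)N(CCCn2ccnc2)C1=O` gives 31700 nM.
Compound 2 `CCCCCOC1=C(C(=O)c2ccccc2)C(c2ccc(Br)cc2)N(CCCn2ccnc2)C1=O` gives 9990 nM.
Compound 3 `O=C(C1=C(Nc2ccccc2)C(=O)N(CCCn2ccnc2)C1c1ccc(Br)cc1)c1ccccc1` gives 24400 nM.

Compound 1 stands highest of the three numbers in this assay. Its nearest neighbour is compound 3, whose step from compound 1 lies within the scatter; the furthest is compound 2, reached by a 3.2-fold lower number from compound 1 to compound 2 (0.50 log units; beyond the scatter).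

Compound 4 `O=C(C1=C(Nc2cccc(Br)c2)C(=O)N(CCCn2ccnc2)C1c1ccc(Br)cc1)c1ccccc1` differs from compound 1 by (3-bromophenyl)amino in place of ethoxy on a double-bonded ring carbon.

Within the data shown here, two measured steps bear on this change. The closest is a 1.3-fold lower number from compound 1 to compound 3 (0.11 log units; within the scatter), where the same kind of swap, anilino for ethoxy, moved the number only within the scatter. The other is a 2.4-fold higher number from compound 2 to compound 3 (0.39 log units; beyond the scatter), which shows the anilino compound sitting somewhat higher than the pentyloxy one. Among the measured compounds shown here, no measured pair tells what a bromine on the entering ring does. On this basis only a small step is expected in this assay, most likely a slight lowering or none beyond the scatter, and compound 4 is expected to land near compound 3.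

Compound 4 is estimated at 20000 nM, with a range from 8000 nM to 50000 nM, meaning an expected step of a 1.6-fold lower number from compound 1 to compound 4 (0.20 log units; within the scatter).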

Compound 4, half-maximal inhibitory concentration: 9090 nM
Beside the measured number, compound 4's estimate is 2.2-fold (0.34 log units) above it; the measured number falls inside the stated range.
By their numbers in this assay, from the lowest: compounds 4 and 2 (each within the scatter of the next); then compounds 3 and 1 (each within the scatter of the next).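

In this assay the bromo on the entering ring makes the difference (a 2.7-fold lower number from compound 3 to compound 4 (0.43 log units; beyond the scatter)), whereas plain anilino had stayed within the scatter of the ethoxy compound. The whole swap of ethoxy for (3-bromophenyl)amino on the double-bonded ring carbon thus yields a real, if modest, gain (a 3.5-fold lower number from compound 1 to compound 4 (0.54 log units; beyond the scatter)), which anilino alone did not give. The (3-bromophenyl)amino and pentyloxy groups end level at this carbon (a 1.1-fold lower number from compound 2 to compound 4 (0.04 log units; within the scatter)), so two quite different groups reach the same range, and no measurement given here accounts for the bromo step.

On these data alone, whether a chloro or methoxy group in place of the bromo on the entering ring would move the number in the same way stays open. Also open, as far as these compounds go, is whether a longer chain than pentyloxy, or a benzylamino group, would go lower still at this carbon.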